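Swapping One Chain End on Compound 2

A few compounds are considered here, and "the series" means these few. Any claim that something is new, unique, unknown or untested is made for them only; others in the source may bear on it.

Of the compounds shown here, three have been tested so far, and none yields a number. In an ADME assay on Vero cells (Chlorocebus sabaeus) for cytotoxicity, read by resazurin assay, with a stated time of 72 h (a higher number here means that more compound is needed for the effect, a lower number that less compound is needed), compound 2 (`FC(F)(F)SCCOc1ccc(Oc2ccccc2)cc1`) reads > 20 uM as a limit of the assay, not a number. Compound 1 (`N#C[Se]C[C@H]1Cc2ccc(Oc3ccccc3)cc2O1`) reads > 20 uM as a limit too. Compound 3 (`FC(F)(F)[Se]CCOc1cccc(Oc2ccccc2)c1`) also reads > 20 uM as a limit. Taken together, the record shows the limit of > 20 uM in this assay, at which 3 of the 3 values shown sit, and nothing more precise, so compound 2 cannot be ranked against the other two.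

Compound 4 (`N#CCCCOc1ccc(Oc2ccccc2)cc1`) has not yet been measured. It carries cyanomethyl in place of (trifluoromethyl)sulfanyl on a saturated chain carbon, two bonds along the chain from an oxygen on an aromatic ring. Cut one bond further out, the same difference reads 2-((trifluoromethyl)sulfanyl)ethyl to 3-cyanopropyl.

Going by the values given here, no two measured compounds differ in just one place, so no measured step can serve as a guide. The expectation rests on compound 2 at > 20 uM as a limit. The step that the limit leaves unreadable from compound 2 to compound 4 is expected to stay within the usual scatter of this assay and to favour neither direction. A report of only a limit is the likeliest outcome. For compound 4 the estimated value is 30 uM with an expected range from 15 uM to 60 uM in this measurement.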

Compound 4, concentration for half-maximal effect: > 20 uM
Compound 4: a limit, no number (the forecaster's own chance of this, stated with the estimate: 75%); the middle value is on the limit's open side.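

Compound 2 and compound 4 both give only a limit, so no step between them can be read: the limit of > 20 uM in this assay, at which 4 of the 4 values shown sit.

The compounds shown leave open whether cyanomethyl in place of (trifluoromethyl)sulfanyl changes the read-out at all, and at what concentration any of these four compounds would reach the half-maximal effect in this assay.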